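Methoxy Analogue in a Series Without Cytotoxicity

The compounds below may be only part of what the source reports. "The series", "measured", "known", "first", "only" and "open" are said of these compounds alone.

Three amides that share the core of compound 1 `COC(=O)c1cccc(C(=O)N2CCCC(C(=O)Nc3ccc(Cl)cc3)C2)c1` have been examined in an ADME assay on PC-3 cells (Homo sapiens) for cytotoxicity, read by WST assay, tested at 100 uM; on this read-out lower numbers stand for less inhibition and higher numbers for more inhibition at the one concentration tested (going by the name of the read-out). Compound 1 gives 0%. Compound 2 `CC(=O)Nc1cccc(C(=O)N2CCCC(C(=O)Nc3ccc(Cl)cc3)C2)c1` gives 4%, and compound 3 `CS(=O)(=O)c1cccc(C(=O)N2CCCC(C(=O)Nc3ccc(Cl)cc3)C2)c1` gives 2%. Among these three numbers compound 3 stands second highest; its nearest neighbour is compound 1 and its furthest is compound 2, and both gaps lie within the scatter, so no order can be read from them. The single-point steps already measured were all small: a number 4 percentage points higher from compound 1 to compound 2 (within the scatter), a number 2 percentage points higher from compound 1 to compound 3 (within the scatter) and a number 2 percentage points lower from compound 2 to compound 3 (within the scatter).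

Compound 4 `COc1cccc(C(=O)N2CCCC(C(=O)Nc3ccc(Cl)cc3)C2)c1` has not yet been tested. It differs from compound 3 in one place: methoxy in place of methylsulfonyl on an aromatic carbon. The step from compound 2 to compound 3, which also exchanges one group on an aromatic carbon, bears most directly on it and stayed within the scatter, as did the two other steps. Compound 4 is therefore expected to show no step beyond the scatter, an estimated no change at the digits printed from compound 3 to compound 4 (within the scatter) in this assay. Compound 4 is expected to give 2%, with a range from -5% to 10%.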

Compound 4, a percentage reported as inhibition, at one concentration (the size of the read-out at that concentration, not a potency): 0%
Compound 4: middle estimate off by 2 percentage points, on the high side, within the range that was stated.
By their numbers in this assay, from the lowest: compounds 1, 4, 3 and 2 (each within the scatter of the next).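

In this assay the change to methoxy stays small against each of the other three groups, with a number 2 percentage points lower from compound 3 to compound 4 (within the scatter), a number 4 percentage points lower from compound 2 to compound 4 (within the scatter) and no change at the digits printed from compound 1 to compound 4 (within the scatter). This place, on an aromatic carbon meta to a large group, therefore shows no step beyond the scatter even with methoxy, which has 2 heavy atoms against the 4 of methylsulfonyl and, unlike the other three groups, no double bond outside the aromatic ring. Nothing measured here offers an explanation for these numbers.

Going by these compounds, whether an amine or a carboxylic acid at this place would move the number beyond the scatter remains open. So does the question of whether a longer alkoxy chain would leave it as unchanged as methoxy does.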